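A few compounds are considered here, and "the series" means these few. Any claim that something is new, unique, unknown or untested is made for them only; others in the source may bear on it.

Compound 1 `COc1cccc([C@@H]2[C@H](Oc3ccccc3)C(=O)N2c2cc(OC)c(OC)c(OC)c2)c1` gives 171000 nM in a functional assay on MCF7 cells (Homo sapiens) for antiproliferative activity, read by MTT assay, with stated times of 24 h and 72 h; on this read-out higher numbers stand for weaker inhibition and lower numbers for stronger inhibition.
Compound 2 `COc1ccc([C@@H]2[C@H](Oc3ccccc3)C(=O)N2c2cc(OC)c(OC)c(OC)c2)cc1OC` gives 26000 nM in this assay.
Compound 3 `COc1cc(N2C(=O)[C@@H](Oc3ccccc3)[C@H]2c2ccc(C#N)cc2)cc(OC)c1OC` gives 31600 nM in this assay.

Among these three, compound 2 has the lowest number in this assay, though compound 3 sits within the scatter of it; only compound 1 stands clearly apart, the gap being a 6.6-fold lower number from compound 1 to compound 2 (0.82 log units; beyond the scatter). The step of a 5.4-fold lower number from compound 1 to compound 3 (0.73 log units; beyond the scatter) shows that the aryl group on the saturated ring carbon can be exchanged with a modest gain, while a 1.2-fold higher number from compound 2 to compound 3 (0.08 log units; within the scatter) shows that two quite different aryl groups at that position give the same result within the scatter.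

Compound 4 `COc1cc(N2C(=O)[C@@H](Oc3ccccc3)[C@H]2c2cc(O)c(OC)c([N+](=O)[O-])c2)cc(OC)c1OC` is not yet measured. It differs from compound 2 as follows: a group of 12 heavy atoms (7 carbon, 1 nitrogen, 4 oxygen; one six-membered aromatic ring of carbon only) in place of a group of 10 heavy atoms (8 carbon, 2 oxygen; one six-membered aromatic ring of carbon only), on a saturated ring carbon. Within the data shown here, no measured step alters a hydroxyl or nitro group, so the direct bearing is limited. Among the measured compounds shown here, what the measured steps do show is that the aryl group at this position tolerates exchange without a change beyond the scatter, as in a 1.2-fold higher number from compound 2 to compound 3 (0.08 log units; within the scatter), whereas only the step from compound 1 moved the number clearly. The expected step is therefore a 1.3-fold lower number from compound 2 to compound 4 (0.11 log units; within the scatter), within the scatter. Compound 4 is estimated at 20000 nM, between 5000 nM and 80000 nM.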

Compound 4, half-maximal inhibitory concentration: 69000 nM
Compound 4: the middle estimate sits 3.5-fold (0.54 log units) below what was measured; the range from low to high includes it.
By their numbers in this assay, from the lowest: compounds 2 and 3 (each within the scatter of the next); then compound 4; then compound 1.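

In this assay, among these compounds, the aryl group on the saturated ring carbon proves less forgiving than the earlier exchange between 3,4-dimethoxyphenyl and 4-cyanophenyl suggested: the aryl group bearing hydroxyl, methoxy and nitro groups gives a 2.7-fold higher number from compound 2 to compound 4 (0.42 log units; beyond the scatter) and also a 2.2-fold higher number from compound 3 to compound 4 (0.34 log units; beyond the scatter) and so becomes the first exchange to move the number upward, beyond the scatter, from both of those compounds. The loss is only partial, since there is still a 2.5-fold lower number from compound 1 to compound 4 (0.39 log units; beyond the scatter) and compound 4 therefore takes a place of its own in the order, with the 3-methoxyphenyl group of compound 1 remaining the least favourable aryl group of the four. No supporting data are available that would explain this step.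

The change brings in the hydroxyl and the nitro group together, so the compounds shown do not tell which of them, or whether the two jointly, accounts for the step. As far as these compounds go, it also remains open how this position would respond to an amine or a carboxylic acid on the aryl ring, or to a change at the phenoxy group on the neighbouring ring atom.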